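Replacing the 4-fluorophenyl of compound 2 with trifluoromethyl

The compounds below may be only part of what the source reports. "The series", "measured", "known", "first", "only" and "open" are said of these compounds alone.

In an ADME assay on the whole organism (Mus musculus, strain Swiss Webster) for pharmacokinetics, read by LC-MS, at a dose of 50 mg/kg by the oral route (on this read-out higher numbers stand for higher exposure at the dose given and lower numbers for lower exposure), compound 2 `O=C(Nc1ccc(F)c(-c2nc3ncc(-c4ccc(F)cc4)cc3[nH]2)c1)N1CCCC1` gives 10200 ng.h/mL. Among the measured compounds shown here, compound 1 `O=C(Nc1ccc(F)c(-c2nc3ncc(-c4ccc(F)c(F)c4)cc3[nH]2)c1)N1CCCC1` gives 12000 ng.h/mL, which is within the scatter of compound 2, so these two share the low end of the numbers so far. Compound 3 `Cc1nc(C)c(C(=O)Nc2ccc(F)c(-c3nc4ncc(-c5ccccc5Cl)cn4n3)c2)o1` differs from both in more than one place and gives a much higher 309000 ng.h/mL.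

Compound 4 `O=C(Nc1ccc(F)c(-c2nc3ncc(C(F)(F)F)cc3[nH]2)c1)N1CCCC1` changes compound 2 at a single place: trifluoromethyl in place of 4-fluorophenyl on an aromatic carbon. Trifluoromethyl in place of 4-fluorophenyl removes a whole ring. For the measured compounds named here, the only measured step that bears on this is a 1.2-fold lower number from compound 1 to compound 2 (0.07 log units; within the scatter). That step touches the same ring but only swaps a fluoro for hydrogen, so it is weak evidence for removing the ring altogether. Compound 3 is too different to serve as a guide.

With so little to go on, no change beyond the scatter is expected, and the estimated step is a 1.2-fold higher number from compound 2 to compound 4 (0.07 log units; within the scatter). The estimate for compound 4 is 12000 ng.h/mL, with an expected range from 3000 ng.h/mL to 50000 ng.h/mL.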

Compound 4, area under the concentration-time curve: 489 ng.h/mL
Compound 4: middle estimate off by 25-fold (1.39 log units), on the high side; measured number below the stated range.
By their numbers in this assay, from the lowest: compound 4; then compounds 2 and 1 (each within the scatter of the next); then compound 3.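

In this assay, swapping a fluoro for hydrogen on the ring stayed within the scatter, but replacing the whole 4-fluorophenyl with trifluoromethyl gives a 21-fold lower number from compound 2 to compound 4 (1.32 log units; beyond the scatter). Replacing 3,4-difluorophenyl in the same way gives a 25-fold lower number from compound 1 to compound 4 (1.39 log units; beyond the scatter), so both ring-bearing compounds lose heavily when the ring goes. This position therefore shows little response to a fluoro change on the ring yet a large one to losing the ring, and nothing available here explains the fall.

Going by these compounds, it remains open whether any ring at this position would keep the higher numbers, or only a fluorinated phenyl would. A pyridyl ring, a cyclohexyl ring or a plain methyl group here would help separate the effect of the ring from that of the trifluoromethyl group.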